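From a bromophenyl limit to a hydroxyphenyl estimate

The compounds below may be only part of what the source reports. "The series", "measured", "known", "first", "only" and "open" are said of these compounds alone.

Compounds measured so far in a functional assay on A549 cells (Homo sapiens) for cytotoxicity, read by MTT assay, with a stated time of 72 h (a higher number here means a weaker inhibitor, a lower number a stronger inhibitor), are these
- compound 1 `COc1cccc(/C=C2\CCC/C(=C\c3cc(Cl)cc(Cl)c3)C2=O)c1OC` gives 12500 nM as its value
- compound 2 `COc1ccc(/C=C2\CCC/C(=C\c3ccc(Cl)cc3)C2=O)cc1OC` gives 10100 nM as its value
- compound 3 `COc1ccc(/C=C2\CCC/C(=C\c3ccccc3Br)C2=O)cc1OC` gives > 20000 nM as a limit

Compound 3 gives > 20000 nM as a limit of the assay and not a number. It sits at the limit of > 20000 nM in this assay, at which 1 of the 3 values shown sits, and no closer figure exists for it.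

Compound 4 `COc1ccc(/C=C2\CCC/C(=C\c3ccc(O)cc3)C2=O)cc1OC` has not yet been measured. It differs from compound 3 by 4-hydroxyphenyl in place of 2-bromophenyl on a double-bonded chain carbon bound to a double-bonded ring carbon so that 4-hydroxyphenyl stands in place of 2-bromophenyl on a double-bonded chain carbon bound to a double-bonded ring carbon.

Within the data shown here, only one measured step bears on this place, and it also involves 2-bromophenyl: an at least 1.9-fold higher number from compound 2 to compound 3 (0.29 log units; that floor lies within the scatter) in the same read-out. That step is small, and it is only a floor. Compound 2 carries 4-chlorophenyl at this place and gives 10100 nM here, so a modest move toward a lower number is expected on leaving 2-bromophenyl, though the move may not clear the scatter.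

The expected change is an at least 1.8-fold lower number from compound 3 to compound 4 (0.25 log units; that floor lies within the scatter) on this estimate. Compound 4 is expected at 11000 nM in this assay with an estimated range of 4500 nM to 20000 nM in that read-out.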

Compound 4, half-maximal inhibitory concentration: > 20000 nM
Compound 4 was reported as a limit; the forecaster's own chance of this, stated with the estimate: 20%; middle value at least 1.8-fold (0.25 log units) away from the limit.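

The reading for compound 4 is a limit of the assay and not a number, so the 4-hydroxyphenyl group joins the 2-bromophenyl group there: the limit of > 20000 nM in this assay, at which 2 of the 4 values shown sit.

Among these compounds, the one readable comparison in this assay is the swap of hydroxy in place of chloro on an aromatic carbon, which gives an at least 1.9-fold higher number from compound 2 to compound 4 (0.29 log units; that floor lies within the scatter); because this is only a floor, the swap cannot yet be called a real loss, although the true gap could be larger. The step between compound 3 and compound 4 cannot be read at all, since neither end has a number. What is new is that the group carrying a hydrogen-bond donor and acceptor gives no readable number here either, so among these three compounds with the same 3,4-dimethoxyphenyl partner, only the 4-chlorophenyl group of compound 2 does.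

Going by these compounds, how far compound 3 and compound 4 lie past the limit remains unknown, so they cannot be ranked against each other. Also open, on these data alone, is whether an amine on the same aromatic carbon, as in a 4-aminophenyl group, would give a readable number or would sit at the limit as well.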